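The source may report more compounds than this note shows. Statements on the series, on what has been measured and on what is new or still open speak of the compounds shown alone.

In a functional assay on DU-145 cells (Homo sapiens) for cytotoxicity, read by trypan blue exclusion, with a stated time of 96 h (on this read-out lower numbers stand for stronger inhibition and higher numbers for weaker inhibition), compound 1 (`COc1cc(OC)c(/C=C/S(=O)(=O)Cc2ccc(OC)c(N)c2)c(OC)c1`) gives 4 nM and compound 2 (`COC(=O)C(Nc1cc(CS(=O)(=O)/C=C/c2c(OC)cc(OC)cc2OC)ccc1OC)c1ccc(F)cc1`) gives 300 nM as the higher of the two numbers. Within the data shown here, the single measured step (a 75-fold higher number from compound 1 to compound 2 (1.88 log units; beyond the scatter)) is large and beyond the scatter, and it comes with (4-fluorophenyl)(methoxycarbonyl)methyl in place of hydrogen on a nitrogen on an aromatic ring.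

Compound 3 (`COC(=O)C(Nc1cc(CS(=O)(=O)/C=C/c2c(OC)cc(OC)cc2OC)ccc1OC)c1ccc(OC)cc1`) differs from compound 2 in one place, with methoxy in place of fluoro on an aromatic carbon, para to a large group (methoxy in place of fluoro on an aromatic carbon). The same difference reads 4-fluorophenyl to 4-methoxyphenyl.

Among the measured compounds shown here, no measured step changes this place. The large step concerns the whole added group, not the swap at hand, and it gives no direction for the change in this assay here. The expectation therefore starts from compound 2 at 300 nM and foresees no step beyond the scatter, in either direction. The expected step (a 1.2-fold lower number from compound 2 to compound 3 (0.08 log units; within the scatter)) is small, though the data are thin and the range stays wide. Compound 3 is estimated at 250 nM within an expected range of 80 nM to 800 nM for this read-out.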

Compound 3, half-maximal inhibitory concentration: 250 nM
For compound 3 middle estimate and measured number coincide at the digits printed; low and high end bracket the measured number.
By their numbers in this assay, from the lowest: compound 1; then compounds 3 and 2 (each within the scatter of the next).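

In this assay, methoxy in place of fluoro on an aromatic carbon, para to a large group, gives a 1.2-fold lower number from compound 2 to compound 3 (0.08 log units; within the scatter). This place within the added (4-fluorophenyl)(methoxycarbonyl)methyl group therefore takes a methoxy, which counts a hydrogen-bond acceptor where fluoro counts none, with no shift beyond the scatter, and this one swap stays far smaller than a 75-fold higher number from compound 1 to compound 2 (1.88 log units; beyond the scatter). No supporting measurement bears on why the two substituents read alike here, so the pair stands as an observation only.

Open is whether an amine, a carboxylic acid or a longer chain such as butoxy at the same aromatic carbon would also stay within the scatter, since fluoro and methoxy are the only two substituents shown there. Also open, going by these compounds, is which part of the added group goes with the large step from the parent amine, the 4-substituted phenyl or the methoxycarbonyl, as both enter together and a replacement of the methyl ester by a carboxylic acid or an amide would be needed to separate them.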